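A few compounds are considered here, and "the series" means these few. Any claim that something is new, unique, unknown or untested is made for them only; others in the source may bear on it.

In a functional assay on L1210 cells (Mus musculus) for inhibition (on this read-out higher numbers stand for weaker inhibition and lower numbers for stronger inhibition), compound 1 `C=C1[C@@H](O)[C@H](n2cnc3c(N)nc(N)nc32)O[C@@H]1CO` gives only a limit, > 200000 nM. Compound 2 `C=C1[C@@H](O)[C@H](n2cnc3c(O)nc(N)nc32)O[C@@H]1CO` also gives only a limit, > 200000 nM. Compound 3 `C=C1[C@@H](O)[C@H](n2cnc3c(N(C)C)nc(N)nc32)O[C@@H]1CO` stands in the same place, with no actual number, just the limit > 500000 nM. Compound 4 `C=C1[C@@H](O)[C@H](n2cnc3c(OC)nc(N)nc32)O[C@@H]1CO` carries methoxy in place of the dimethylamino of compound 3 on an aromatic carbon (methoxy in place of dimethylamino on an aromatic carbon). The measured steps that bear on this swap, a step that the two limits leave unreadable from compound 1 to compound 3 and a step that the two limits leave unreadable from compound 2 to compound 3, have no readable size, so no clear step in either direction is expected in this assay. The estimate therefore means an expected step of an at least 2.0-fold lower number from compound 3 to compound 4 (0.30 log units; that floor lies within the scatter), which should not be read as a real change. Compound 4 is estimated at 250000 nM, with an expected range of 100000 nM to 500000 nM, and will most likely be reported as a limit again.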

Compound 4, half-maximal inhibitory concentration: 446000 nM
For compound 4 the middle estimate is 1.8-fold (0.25 log units) below the measured one; low and high end bracket the measured number.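

In this assay, among the compounds shown here, compound 4 is the first compound here to give an actual number rather than a limit, 446000 nM, so a group on this aromatic carbon can now be placed on the scale. The swap to methoxy amounts to an at least 1.1-fold lower number from compound 3 to compound 4 (0.04 log units; that floor lies within the scatter), so no real change can be claimed. The steps from compound 1 and compound 2 to compound 4 cannot be read.

From the compounds shown here alone, whether a longer chain such as butoxy, or a chlorine atom, on this carbon would give a clearly lower number stays open.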